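Replacing Cyclopropylcarbamoyl with Methoxymethyl

This account rests on a few compounds, and the source may have more. Where it says the series, first, only, none or still open, it means among the compounds named here.

Among the compounds with values here, in a functional assay on OVCAR-8 cells (Homo sapiens) for antiproliferative activity (a lower number here means a stronger inhibitor, a higher number a weaker inhibitor), compound 1 (`Cn1ncc(Cl)c1-c1cc(C(=O)N[C@@H]2CN[C@H](CC(=O)NCC(O)CO)C[C@H]2c2ccc(Cl)c(Cl)c2)oc1Cl`) gives 5900 nM and compound 2 (`Cn1ncc(Cl)c1-c1cc(C(=O)N[C@@H]2CN[C@H](CC(=O)NC3CC3)C[C@H]2c2ccc(Cl)c(Cl)c2)oc1Cl`) gives 580 nM, so compound 2 holds the lower of the two numbers so far. Within the data shown here, the only measured step, a 10-fold lower number from compound 1 to compound 2 (1.01 log units; beyond the scatter), put cyclopropyl in place of 2,3-dihydroxypropyl on an amide-type nitrogen. Compound 3 (`COCC[C@@H]1C[C@@H](c2ccc(Cl)c(Cl)c2)[C@H](NC(=O)c2cc(-c3c(Cl)cnn3C)c(Cl)o2)CN1`) keeps the shared core but alters that same side chain: methoxymethyl in place of cyclopropylcarbamoyl on a saturated chain carbon bound to a saturated ring carbon. Among the measured compounds shown here, the large measured step kept the amide, whereas this change removes it, so that step is only a loose guide, and no measured pair tests the new change directly. The estimate therefore starts from compound 2 at 580 nM. The expected change is a 1.5-fold lower number from compound 2 to compound 3 (0.16 log units; within the scatter), a small step not expected to clear the usual scatter. For compound 3 the estimated value is 400 nM, with an expected range from 130 nM to 1200 nM.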

Compound 3, half-maximal inhibitory concentration: 1060 nM
Compound 3: the middle estimate sits 2.7-fold (0.42 log units) below what was measured; the measured number falls inside the stated range.
By their numbers in this assay, from the lowest: compounds 2 and 3 (each within the scatter of the next); then compound 1.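

In this assay the amide on this side chain proves not to be required: methoxymethyl in place of cyclopropylcarbamoyl gives a 1.8-fold higher number from compound 2 to compound 3 (0.26 log units; within the scatter) and so compound 2 and compound 3 cannot be told apart, even though the three-membered ring and the hydrogen-bond donor are gone. Methoxymethyl in place of (2,3-dihydroxypropyl)carbamoyl gives a 5.6-fold lower number from compound 1 to compound 3 (0.75 log units; beyond the scatter) and so compound 1 now stands apart from both of the others, with the highest number of the three. No measured evidence explains these results.

The compounds shown leave open whether an amine or a carboxylic acid on this chain would fall with compound 2 and compound 3 or with compound 1. They also leave open how a longer ether chain would compare with methoxymethyl at this place.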